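A side chain exchanged on a shared core

The compounds below may be only part of what the source reports. "The series", "measured", "known", "first", "only" and "open" are said of these compounds alone.

Values in a functional assay on the whole organism for inhibition, with Mus musculus as the target; on this read-out lower numbers stand for an effect already at smaller amounts and higher numbers for an effect only at larger amounts of compound:
- compound 1 `CN1Cc2c(N)cccc2C(c2ccc(F)cc2)C1`: about 3.6 mg/kg
- compound 2 `CCCCNC(=O)Nc1cccc2c1CN(C)CC2c1ccccc1`: about 40 mg/kg
- compound 3 `CCCCNC(=O)Nc1cccc2c1CN(C)CC2c1ccc(C)cc1`: 40 mg/kg

In this assay compound 2 is level with compound 3, and together they hold the highest number of the three, well above compound 1 at about 3.6 mg/kg.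

Compound 4 `CCNCCC(=O)Nc1cccc2c1CN(C)CC2c1ccccc1` is not yet measured. It differs from compound 2 by 2-(ethylamino)ethyl in place of butylamino on a carbonyl carbon. For the measured compounds named here, the one measured step, no change at the digits printed from compound 2 to compound 3 (within the scatter), is methyl in place of hydrogen on an aromatic carbon, so no measured step touches this group. The expectation therefore starts from compound 2 at about 40 mg/kg, with no step beyond the scatter foreseen. The estimate is a 1.3-fold lower number from compound 2 to compound 4 (0.12 log units; within the scatter). For compound 4 the estimated value is 30 mg/kg, with an expected range from 10 mg/kg to 100 mg/kg.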

Compound 4, dose for half-maximal effect: > 200 mg/kg
Compound 4: no number, only a limit (the forecaster's own chance of this, stated with the estimate: 15%); at least 6.6-fold (0.82 log units) between middle value and limit.
By their numbers in this assay, from the lowest: compound 1; then compounds 2 and 3 (each within the scatter of the next). At a limit, above all of these: compound 4.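

In this assay the group on the carbonyl carbon proves sensitive: 2-(ethylamino)ethyl in place of butylamino, with the same atoms joined differently, gives a clear step (an at least 5.0-fold higher number from compound 2 to compound 4 (0.69 log units; beyond the scatter)). The methyl on the aromatic carbon gave no hint of this (no change at the digits printed from compound 2 to compound 3 (within the scatter)), as that step lies elsewhere on the shared core. The result for compound 4 is a limit and not a number: the limit of > 200 mg/kg in this assay, at which 1 of the 4 values shown sits.

Going by these compounds, how far compound 4 actually lies from compound 2 remains open. So does whether a longer alkyl chain or a carboxylic acid on this carbonyl carbon would keep the number of compound 2.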